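The compounds below may be only part of what the source reports. "The series", "measured", "known", "first", "only" and "open" are said of these compounds alone.

Compound 1 `CCc1cn(-c2nc(NC)c3ncn([C@@H]4O[C@H](CO)[C@@H](O)[C@H]4O)c3n2)nn1`: 2920 nM in an assay on CHO cells for displacement of a labelled ligand from adenosine receptor A1 (Homo sapiens); a lower number here means a stronger inhibitor, a higher number a weaker inhibitor
Compound 2 `CCCCc1cn(-c2nc(NC)c3ncn([C@@H]4O[C@H](C(=O)NCC)[C@@H](O)[C@H]4O)c3n2)nn1`: 750 nM in this assay
Compound 3 `CCCCc1cn(-c2nc(NC)c3ncn([C@@H]4O[C@H](CO)[C@@H](O)[C@H]4O)c3n2)nn1`: 848 nM in this assay

Among these three numbers compound 2 holds the lowest, but its separation from compound 3 is only a 1.1-fold higher number from compound 2 to compound 3 (0.05 log units; within the scatter), within the scatter; only compound 1 stands clearly apart. Compound 4 `CCNC(=O)[C@H]1O[C@@H](n2cnc3c(NC)nc(-n4ccnn4)nc32)[C@H](O)[C@@H]1O` differs from compound 2 by hydrogen in place of butyl on an aromatic carbon. The step that bears on this change is a 3.4-fold lower number from compound 1 to compound 3 (0.54 log units; beyond the scatter), which shows that lengthening the chain on the triazole carbon lowers the number; removing the chain altogether reverses and likely exceeds that step. Because a 1.1-fold higher number from compound 2 to compound 3 (0.05 log units; within the scatter) is within the scatter, compound 2 is taken as a fair starting point. Compound 4 is therefore expected to give a clearly higher number, a 6.7-fold higher number from compound 2 to compound 4 (0.82 log units; beyond the scatter), with an estimate of 5000 nM in a range of 1500 nM to 20000 nM.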

Compound 4, inhibition constant: 590 nM
Compound 4: the middle estimate sits 8.5-fold (0.93 log units) above what was measured; the whole stated range lies above it.
By their numbers in this assay, from the lowest: compounds 4, 2 and 3 (each within the scatter of the next); then compound 1.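

In this assay, replacing butyl with hydrogen on the aromatic carbon gives a 1.3-fold lower number from compound 2 to compound 4 (0.10 log units; within the scatter) and so does not separate the two compounds. With hydroxymethyl on the saturated ring carbon, the longer chain had given a 3.4-fold lower number from compound 1 to compound 3 (0.54 log units; beyond the scatter). Compound 2 and compound 4 go against any rule that chain length at this position sets the number when ethylcarbamoyl is present. Nothing measured here accounts for this result.
As far as these compounds go, it remains open how hydrogen at this carbon behaves alongside hydroxymethyl, and how an amine or a phenyl group there would compare.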